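A few compounds are considered here, and "the series" means these few. Any claim that something is new, unique, unknown or untested is made for them only; others in the source may bear on it.

In a functional assay on HT-29 cells (Homo sapiens) for antiproliferative activity, read by sulforhodamine B assay, with a stated time of 48 h (on this read-out higher numbers stand for weaker inhibition and lower numbers for stronger inhibition), compound 3 (`Cc1ccc(C)c(NS(=O)(=O)c2ccc(N3CCNC3=O)cc2)c1`) gives the lowest number of the three measured compounds (46 nM), with compound 1 (`Cc1cccc(NS(=O)(=O)c2ccc(N3CCNC3=O)cc2)c1`) at 110 nM and compound 2 (`O=C1NCCN1c1ccc(S(=O)(=O)Nc2ccccc2)cc1`) at 280 nM. Compound 4 (`Cc1ccc(NS(=O)(=O)c2ccc(N3CCNC3=O)cc2)c(C)c1`) has the same atoms joined differently, with 2,4-dimethylphenyl in place of 2,5-dimethylphenyl on a sulfonamide nitrogen. Among the compounds with values here, no measured step shows such a rearrangement. The nearest evidence is the set of changes on the same aromatic group, all modest: a 2.5-fold higher number from compound 1 to compound 2 (0.41 log units; beyond the scatter) and a 2.4-fold lower number from compound 1 to compound 3 (0.38 log units; beyond the scatter) and also a 6.1-fold lower number from compound 2 to compound 3 (0.78 log units; beyond the scatter) in this series. A step no larger than these is therefore expected, estimated as a 1.4-fold higher number from compound 3 to compound 4 (0.15 log units; within the scatter) on this read-out, with a rise somewhat likelier than a fall. The estimated value for compound 4 is 65 nM (expected range 22 nM to 190 nM).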

Compound 4, half-maximal inhibitory concentration: 180 nM
Compound 4: the middle estimate sits 2.8-fold (0.44 log units) below what was measured; low and high end bracket the measured number.
By their numbers in this assay, from the lowest: compound 3; then compounds 1, 4 and 2 (each within the scatter of the next, the first and the last beyond it).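

Rearranging the two methyl groups matters in this assay: the change gives a 3.9-fold higher number from compound 3 to compound 4 (0.59 log units; beyond the scatter) even though the atoms stay the same. Having two methyl groups on the phenyl is therefore not enough in itself, since a 1.6-fold lower number from compound 2 to compound 4 (0.19 log units; within the scatter) and a 1.6-fold higher number from compound 1 to compound 4 (0.21 log units; within the scatter) leave compound 4 inseparable from either neighbour. Nothing available explains the difference between the two arrangements. Still open, going by these compounds, is whether a methoxy group, a chlorine or an amine on the phenyl would follow the 2,5-dimethylphenyl or the 2,4-dimethylphenyl result.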